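The compounds below may be only part of what the source reports. "The series", "measured", "known", "first", "only" and "open" are said of these compounds alone.

Compound 2 `CCCS(=O)(=O)Nc1ccc(F)c(C(=O)c2n[nH]c3ncc(-c4ccc(OC)cc4)cc23)c1F` stands second highest of the three numbers seen so far in an assay for binding affinity to dual specificity mitogen-activated protein kinase kinase 4 (Homo sapiens), read by KINOMEscan, tested at 100 nM (on this read-out lower numbers stand for a stronger effect and higher numbers for a weaker effect at the one concentration tested), where compound 2 gives 4.2%. Compound 1 `CCCS(=O)(=O)Nc1ccc(F)c(C(=O)c2n[nH]c3ncc(-c4cccc(OC)c4)cc23)c1F` gives 6.3% in this assay, and compound 3 `CCCS(=O)(=O)Nc1ccc(F)c(C(=O)c2n[nH]c3ncc(-c4cccc(N)c4)cc23)c1F` gives 1.6%. The three steps among them, a number 2.1 percentage points lower from compound 1 to compound 2 (within the scatter), a number 4.7 percentage points lower from compound 1 to compound 3 (within the scatter) and a number 2.6 percentage points lower from compound 2 to compound 3 (within the scatter), all lie within the scatter, so swapping one small group for another on that outer ring has so far left the read-out essentially unchanged. Compound 4 `CCCS(=O)(=O)Nc1ccc(F)c(C(=O)c2n[nH]c3ncc(-c4ccc(S(=O)(=O)NC(C)=O)cc4)cc23)c1F` differs from compound 2 by acetylsulfamoyl in place of methoxy on an aromatic carbon. Going by the values given here, no measured step covers a group of this kind, so the expectation rests only on how little earlier swaps moved the number. Compound 4 is therefore expected to give about 8%, somewhere between 1% and 35%, a step of a number 3.8 percentage points higher from compound 2 to compound 4 (within the scatter) that is estimated to stay within the scatter.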

Compound 4, a percentage reported as activity, at one concentration (the size of the read-out at that concentration, not a potency): 0.35%
Compound 4: the middle estimate sits 7.7 percentage points above what was measured, and the stated range ends above it.
By their numbers in this assay, from the lowest: compounds 4, 3, 2 and 1 (each within the scatter of the next).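

On the carbon ring, para to a large group, the much bigger acetylsulfamoyl, which brings a hydrogen-bond donor that methoxy lacks, can replace methoxy in this assay with only a small shift, a number 3.9 percentage points lower from compound 2 to compound 4 (within the scatter). So this position accepts far more than the small swaps of the earlier compounds could show. Nothing at hand explains this result. On these data alone, whether a carboxylic acid or an amine at this same place would keep the number as low remains open. So does how the acetylsulfamoyl compound would rank at a lower concentration.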